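The source may hold more compounds than are shown below. What is called first, only, known or untested is meant among the compounds shown, and "the series" means these compounds.

Going by the values given here, in an ADME assay on A549 cells (Homo sapiens) for cytotoxicity, read by resazurin assay, with a stated time of 48 h (a higher number here means that more compound is tolerated, a lower number that less compound is tolerated), compound 1 `O=C(Nc1ccc(NCc2ccc(C(F)(F)F)cc2)cc1Cl)c1cc(Cl)ccc1O` gives 62700 nM and compound 2 `O=C(Nc1ccc(NCc2cc(Cl)cc(Cl)c2)cc1Cl)c1cc(Cl)ccc1O` gives 13300 nM as the lower of the two numbers so far. Compound 3 `O=C(Nc1ccc(NCc2ccncc2)cc1Cl)c1cc(Cl)ccc1O` keeps the shared core. The change pyridin-4-yl in place of 3,5-dichlorophenyl on a saturated chain carbon bound to a nitrogen on an aromatic ring puts pyridin-4-yl in place of 3,5-dichlorophenyl on a saturated chain carbon bound to a nitrogen on an aromatic ring. Among the compounds with values here, one measured step bears on this place: a 4.7-fold lower number from compound 1 to compound 2 (0.67 log units; beyond the scatter) came with 3,5-dichlorophenyl in place of 4-(trifluoromethyl)phenyl, and it is modest but beyond the scatter. Within the data shown here, no compound with a hetero atom in this ring has been measured yet, so the guide is thin. Since compound 1 stands at 62700 nM without the 3,5-dichlorophenyl group, leaving that group is expected to raise the number rather than lower it. Among the measured compounds shown here, the expected move is a 3.4-fold higher number from compound 2 to compound 3 (0.53 log units; beyond the scatter) in about the size of the one measured step. For compound 3 the expected value in this assay is 45000 nM with 16000 nM to 120000 nM as the estimated range.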

Compound 3, half-maximal cytotoxic concentration: 65300 nM
Beside the measured number, compound 3's estimate is 1.5-fold (0.16 log units) below it; the range from low to high includes it.
By their numbers in this assay, from the lowest: compound 2; then compounds 1 and 3 (each within the scatter of the next).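

In this assay, the step at this place, on a saturated chain carbon bound to a nitrogen on an aromatic ring, reads a 4.9-fold higher number from compound 2 to compound 3 (0.69 log units; beyond the scatter), so the lower number of compound 2 does not carry over to a ring with a hetero atom. The comparison with the other ring adds a second reference point, a 1.0-fold higher number from compound 1 to compound 3 (0.02 log units; within the scatter), which lies within the scatter: 4-(trifluoromethyl)phenyl and pyridin-4-yl cannot be told apart here, although one ring holds carbon only and the other holds a hetero atom, and among these three compounds only the 3,5-dichlorophenyl group stands apart. No supporting measurement is available to explain why this group differs from the other two.

The compounds shown leave open whether the lower number of compound 2 needs both chlorine atoms, or whether a single chlorine on the phenyl ring or an unsubstituted phenyl would give it as well. They also leave open how a non-aromatic group at this place, such as a saturated cyclic amine or a carboxylic acid, would read in this assay.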